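A few compounds are considered here, and "the series" means these few. Any claim that something is new, unique, unknown or untested is made for them only; others in the source may bear on it.

Measured compounds:
Compound 1 `Clc1cccc(Cc2nnc(Cn3nnc4ccccc43)o2)c1` — in an ADME assay on cells (Macrophage, Homo sapiens) for inhibition (on this read-out higher numbers stand for lower toxicity in this test and lower numbers for higher toxicity in this test), compound 1 gives only the assay limit > 100000 nM.
Compound 2 `Fc1cccc(Cc2nnc(Cn3nnc4ccccc43)o2)c1` — in this assay compound 2 gives only the assay limit > 100000 nM.
Compound 3 `Clc1cccc(-c2nnc(Cn3nnc4ccccc43)o2)c1` — in this assay compound 3 gives only the assay limit > 100000 nM.

From compound 1 to compound 2 the change is fluoro in place of chloro on an aromatic carbon. The step it made in this assay is a step that the two limits leave unreadable from compound 1 to compound 2. All three measured values sit at the same limit (the limit of > 100000 nM in this assay, at which 3 of the 3 values shown sit). The difference between the core of compound 1 and the core of compound 3 is not broken down here.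

Compound 4 `Fc1cccc(-c2nnc(Cn3nnc4ccccc43)o2)c1` has not been measured. It carries the same change as compound 1 to compound 2, namely (fluoro in place of chloro on an aromatic carbon), at the same place. Because compound 3 sits at the limit > 100000 nM, compound 4 is expected to remain at that limit as well. The expected step for compound 4 is estimated as a number no higher from compound 3 to compound 4 (the limit leaves the size open). Compound 4 is estimated at 100000 nM, expected between 50000 nM and 200000 nM.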

Compound 4, half-maximal cytotoxic concentration: > 100000 nM
Compound 4: a limit, no number; the forecaster's own chance of this, stated with the estimate: 85%; the middle value sits exactly at the limit.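

In this assay compound 3 and compound 4 both give only an assay limit, so no step between them can be read: the limit of > 100000 nM in this assay, at which 4 of the 4 values shown sit.
Still open is where the half-maximal cytotoxic concentration of any of these compounds actually lies.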